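A few compounds are considered here, and "the series" means these few. Any claim that something is new, unique, unknown or untested is made for them only; others in the source may bear on it.

Measured in a functional assay on A549 cells (Homo sapiens) for inhibition, read by MTT assay, with a stated time of 72 h; on this read-out lower numbers stand for stronger inhibition and higher numbers for weaker inhibition:

- Compound 1 `Brc1ccc(-c2nnc(SCCCN3CCN(c4nc5ccccc5o4)CC3)o2)cc1`: 123000 nM
- Compound 2 `CC(C)(C)Oc1ccc(-c2nnc(SCCCN3CCN(c4nc5ccccc5o4)CC3)o2)cc1`: 263000 nM

Of these two compounds, compound 1, at 123000 nM, has the lower number and so the stronger inhibition in this assay. Going by the values given here, its only neighbour is compound 2, at 263000 nM.

The next compound, compound 3 `Brc1ccc(-c2nnc(SCCCN3CCN(c4nc5ccccc5s4)CC3)o2)cc1`, keeps the bromo group of compound 1 and changes one group: 1,3-benzothiazol-2-yl in place of 1,3-benzoxazol-2-yl on an amine nitrogen in a ring. In words, 1,3-benzothiazol-2-yl takes the place of 1,3-benzoxazol-2-yl on an amine nitrogen in a ring.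

Among the compounds with values here, only one measured step is available, a 2.1-fold higher number from compound 1 to compound 2 (0.33 log units; beyond the scatter). It is modest, though beyond the scatter, and it comes from tert-butoxy in place of bromo on an aromatic carbon. That is a different change at a different place, so it shows only how small a structural step can move these numbers. Within the data shown here, no measured pair tests the present swap, so no direction can be drawn from the data.

The expected result is a 1.1-fold lower number from compound 1 to compound 3 (0.05 log units; within the scatter), which would not go beyond the scatter. For compound 3 the estimated value is 110000 nM, with an expected range from 50000 nM to 250000 nM.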

Compound 3, half-maximal inhibitory concentration: 62500 nM
Beside the measured number, compound 3's estimate is 1.8-fold (0.25 log units) above it; the measured number falls inside the stated range.
By their numbers in this assay, from the lowest: compounds 3 and 1 (each within the scatter of the next); then compound 2.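

Placing 1,3-benzothiazol-2-yl where 1,3-benzoxazol-2-yl stood, on the amine nitrogen in the ring, gives the first reading at this position in this assay (a 2.0-fold lower number from compound 1 to compound 3 (0.29 log units; within the scatter)), so with the bromo group kept, sulfur in place of oxygen in this group leaves compound 3 and compound 1 not separable by this read-out. The earlier step (a 2.1-fold higher number from compound 1 to compound 2 (0.33 log units; beyond the scatter)) concerned only the group on the aromatic carbon at the other end of the molecule and went beyond the scatter, so the new pair adds that the first change tried at the amine nitrogen did not go beyond it. This holds for this single pair and says nothing yet about other groups at this position, and nothing among the data given explains the result.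

Going by these compounds, it remains open whether the same swap would also stay within the scatter with tert-butoxy on the aromatic carbon instead of bromo. On these data alone, it is equally open whether a different group on this nitrogen, such as a plain phenyl ring or a quinolin-2-yl group, would move the number further.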